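Cyclopropyl for methyl on a second core

The source may hold more compounds than are shown below. What is called first, only, known or untested is meant among the compounds shown, and "the series" means these compounds.

Measured so far:
compound 1 `CCC[C@H](NC(=O)[C@@H]1[C@H]2[C@@H](CN1C(=O)[C@@H](NC(=O)NC1([C@H]3CCCCS3(=O)=O)CCCCC1)C(C)(C)C)C2(C)C)C(=O)C(=O)NC1CC1`: 138 ng.h/mL
compound 2 `CC(C)(C)[C@H](NC(=O)NC1([C@H]2CCCCS2(=O)=O)CCCCC1)C(=O)N1C[C@@H]2[C@H]([C@H]1C(=O)N[C@@H](CCC1CC1)C(=O)C(=O)NC1CC1)C2(C)C`: 574 ng.h/mL
compound 3 `CCC[C@H](NC(=O)[C@@H]1[C@H]2[C@@H](CN1C(=O)[C@@H](NC(=O)NC1([C@H]3CCCS3(=O)=O)CCCCC1)C1(C)CCCCC1)C2(C)C)C(=O)C(=O)NC1CC1`: 862 ng.h/mL

All three were tested in an ADME assay on the whole organism (plasma) for pharmacokinetics, with Rattus norvegicus as the target, with a stated time of 24 h, at a dose of 10 mg/kg by the oral route; a lower number here means less compound in the circulation, a higher number more compound in the circulation at the dose given. Compound 1 and compound 2 share one core and differ in a single place: cyclopropyl in place of methyl on a saturated chain carbon, three bonds along the chain from an amide-type nitrogen and a carbonyl carbon. That change gave a 4.2-fold higher number from compound 1 to compound 2 (0.62 log units; beyond the scatter). Compound 3 sits on a different core, and the difference between the two cores is not broken down here. Compound 3 gives the highest of the three numbers, though its gap to compound 2 lies within the scatter, while its gap to compound 1 lies beyond it.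

Compound 4 `CC1([C@H](NC(=O)NC2([C@H]3CCCS3(=O)=O)CCCCC2)C(=O)N2C[C@@H]3[C@H]([C@H]2C(=O)N[C@@H](CCC2CC2)C(=O)C(=O)NC2CC2)C3(C)C)CCCCC1` has not yet been measured. It differs from compound 3 by cyclopropyl in place of methyl on a saturated chain carbon, three bonds along the chain from an amide-type nitrogen and a carbonyl carbon, the same change, in the same place, that turns compound 1 into compound 2. Among the measured compounds shown here, on that footing, the step in this assay is expected to read a 2.6-fold higher number from compound 3 to compound 4 (0.41 log units; beyond the scatter), a rise taken from the one earlier example, damped because a 4.2-fold higher number from compound 1 to compound 2 (0.62 log units; beyond the scatter) rests on a single pair on another core. Compound 4 is therefore estimated at 2200 ng.h/mL, with a likely range from 900 ng.h/mL to 5000 ng.h/mL.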

Compound 4, area under the concentration-time curve: 1120 ng.h/mL
For compound 4 the middle estimate is 2.0-fold (0.29 log units) above the measured one; the measured number falls inside the stated range.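

On the second core, cyclopropyl in place of methyl gave a 1.3-fold higher number from compound 3 to compound 4 (0.11 log units; within the scatter), so the clear rise seen on the first core does not reappear in a form that can be told apart from ordinary scatter. Set side by side, the two results show that the size of this step in this assay does not carry over unchanged from one core to the other: the same change on two cores in this assay, a 4.2-fold higher number (0.62 log units; beyond the scatter) from compound 1 to compound 2 and a 1.3-fold higher number (0.11 log units; within the scatter) from compound 3 to compound 4, 3.2-fold (0.51 log units) apart, beyond the scatter of two such steps With only one pair on each core, this shows that the surrounding structure matters, but not which part of it does, why it does, or how the step would read on a third core.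

The compounds shown leave open how other groups in this place on the chain would read, such as a cyclobutyl ring, a longer open chain or a chain carrying an ether oxygen. They also leave open whether any such group would behave alike on both cores.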